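The compounds below may be only part of what the source reports. "The series", "measured", "known", "first", "only" and "open" are said of these compounds alone.

Three compounds here share a core built around a benzene ring carrying three methoxy groups, and each has been tested in a functional assay on BGC-823 cells (Homo sapiens) for antiproliferative activity, read by MTT assay, tested at 1 uM; a higher number here means a stronger effect of the compound at the concentration tested, a lower number a weaker effect. Compound 1, `COc1cc(C2=NN(C(C)=O)C(c3cccc(F)c3)O2)cc(OC)c1OC`, has that trimethoxyphenyl part attached to a five-membered non-aromatic ring with two nitrogens and one oxygen, which bears an acetyl group and a 3-fluorophenyl group; in this assay compound 1 gives 14.7%. Compound 2, `COc1cc(C(=O)N/N=C/c2ccccc2F)cc(OC)c1OC`, instead links the trimethoxyphenyl part through an amide to a hydrazone, and in this assay compound 2 gives 51.6%. Compound 3, `COc1cc(/C=N/NC(=O)c2cc(OC)c(OC)c(OC)c2)cc(OC)c1OC`, carries two such trimethoxyphenyl parts joined by an acyl hydrazone, and in this assay compound 3 gives -5%. Among these three numbers compound 1 stands second highest: it lies above compound 3 and below compound 2, and both gaps are beyond the usual scatter.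

Compound 4, `COc1cc(C2=NN(C(C)=O)C(c3ccc(Cl)c(Cl)c3)O2)cc(OC)c1OC`, differs from compound 1 only at the saturated ring carbon: 3,4-dichlorophenyl in place of 3-fluorophenyl on a saturated ring carbon. Because compound 1 gives only 14.7%, the step is expected to be small, at most a modest rise and possibly none beyond the scatter, so an estimated step of a number 5.3 percentage points higher from compound 1 to compound 4 (within the scatter) seems reasonable. Compound 4 is therefore expected to give about 20%, within a range of 2% to 45%.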

Compound 4, a percentage reported as inhibition, at one concentration (the size of the read-out at that concentration, not a potency): -0.8%
The estimate for compound 4 lay 20.8 percentage points above the measured number; the whole stated range lies above it.
By their numbers in this assay, from the lowest: compounds 3 and 4 (each within the scatter of the next); then compound 1; then compound 2.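

Going by these compounds alone, this is the first comparison here that changes one place only, and it shows that the aryl group on the saturated ring carbon matters in this assay. Putting 3,4-dichlorophenyl in place of 3-fluorophenyl gives a number 15.5 percentage points lower from compound 1 to compound 4 (beyond the scatter) on an otherwise unchanged core, so a starting level that was already modest can still fall, and compound 4 gives -0.8% at the concentration tested. Nothing available explains why the change acts in this direction.

The swap removes a fluorine and adds two chlorines in one step, so the compounds shown cannot separate the effect of changing the halogen from that of adding a second one, which a phenyl ring carrying a single chlorine could help to do. On these data alone, it also remains open how this position would respond to a plain phenyl ring or to a phenyl ring carrying an amine or a carboxylic acid, and whether any such group could lift the read-out above that of compound 1 rather than lower it.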